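Lengthening the amine chain on a cinnamanilide core

The source may report more compounds than this note shows. Statements on the series, on what has been measured and on what is new or still open speak of the compounds shown alone.

Three compounds sharing one core, compound 1 `COc1cc(/C=C/C(=O)Nc2ccccc2)ccc1OCCCN(C)C`, compound 2 `COc1cc(/C=C/C(=O)Nc2ccccc2)ccc1OCCCN1CCCCC1` and compound 3 `COc1cc(/C=C/C(=O)Nc2ccccc2)ccc1OCCCCN1CCCC1`, have been examined in a physicochemical assay for lipophilicity, using the shake flask method, measured as octanol-water partition, at pH 7.4; on this read-out higher numbers stand for higher lipophilicity and lower numbers for lower lipophilicity. Compound 1 gives 1.55, compound 2 gives 1.58 and compound 3 gives 1.6. The three numbers sit close together: a number 0.03 log units higher from compound 1 to compound 2 (within the scatter), a number 0.05 log units higher from compound 1 to compound 3 (within the scatter) and a number 0.02 log units higher from compound 2 to compound 3 (within the scatter), so on these data compound 2 is not set apart from either neighbour.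

The next compound, compound 4 `CCN(CC)CCCCCCCCOc1ccc(/C=C/C(=O)Nc2ccccc2)cc1OC`, differs from compound 2 in one place: 5-(diethylamino)pentyl in place of piperidin-1-yl on a saturated chain carbon, three bonds along the chain from an oxygen on an aromatic ring. The measured steps all swap one small amine for another of similar size and show no shift beyond the scatter, so none of them reports what happens when the amine grows by the four extra carbons counted here. That makes them weak guides. What they do show is that the amine end can be varied without moving this assay much; the added chain length, however, is a larger change than any measured step, and the expectation is a rise, estimated as a number 1.32 log units higher from compound 2 to compound 4 (beyond the scatter). For compound 4 the value in this assay is therefore estimated at 2.9, within a range from 2.2 to 3.6.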

Compound 4, partition coefficient: 1.75
Beside the measured number, compound 4's estimate is 1.15 log units above it; the measured number lies below the stated range.
By their numbers in this assay, from the lowest: compounds 1, 2, 3 and 4 (each within the scatter of the next).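

In this assay, within the data shown here, putting 5-(diethylamino)pentyl, with 10 heavy atoms and no ring, in place of piperidin-1-yl, with 6 heavy atoms and one ring, gives a number 0.17 log units higher from compound 2 to compound 4 (within the scatter) and so stays inside the usual scatter even though this change is larger than any step among the earlier compounds. The two other comparisons read the same way, with a number 0.15 log units higher from compound 3 to compound 4 (within the scatter) and a number 0.20 log units higher from compound 1 to compound 4 (within the scatter), which means that the insensitivity seen among the small amines of compounds 1, 2 and 3 also holds, in these four compounds, for an open-chain amine carried on a much longer chain. Nothing available here explains why the four numbers stay so close together.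

Compound 4 differs from compound 2 both in chain length and in the loss of the ring, so the two changes cannot be told apart; a 5-(piperidin-1-yl)pentyl group at the same place would separate them. From the compounds shown here alone, it also remains open whether a morpholine ring or a carboxylic acid at the end of the chain, rather than an amine with only carbon substituents, would produce a step beyond the scatter in this assay at this position.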